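The source may hold more compounds than are shown below. What is called first, only, known or untested is meant among the compounds shown, and "the series" means these compounds.

For the measured compounds named here, in a functional assay on MCF7 cells (Homo sapiens) for antiproliferative activity, read by CCK-8 assay, with a stated time of 72 h (a higher number here means a weaker inhibitor of growth, a lower number a stronger inhibitor of growth), compound 2 (`CC[C@@H]1C(=O)N(C)c2cnc(Nc3ccc(S(=O)(=O)NC)cc3)nc2N1C1CCCC1`) gives 151 nM, the lowest of the three numbers measured so far. Compound 1 (`CCC1C(=O)N(C)c2cnc(-n3ccc4cc(C(=O)NC(C)C)ccc43)nc2N1c1ccn(C)n1`) gives 8420 nM and compound 3 (`CCC1C(=O)N(C)c2cnc(-n3ccc4cc(C(=O)NC)ccc43)nc2N1c1ccn(C)n1`) gives 35400 nM, both far higher. The next analogue is compound 4 (`CC[C@@H]1C(=O)N(C)c2cnc(Nc3ccc(S(N)(=O)=O)cc3)nc2N1C1CCCC1`), which departs from compound 2 in one place: hydrogen in place of methyl on a sulfonamide nitrogen. Going by the values given here, no measured pair changes the sulfonamide itself. Among the compounds with values here, the nearest precedent is a 4.2-fold higher number from compound 1 to compound 3 (0.62 log units; beyond the scatter), with methyl in place of isopropyl on an amide-type nitrogen. That step is modest, but it lies on a different nitrogen in structures quite unlike compound 2, so it offers only weak guidance. A small change in this assay is therefore expected, possibly none beyond the scatter, with a slight lean towards a higher number. The expected step is a 1.3-fold higher number from compound 2 to compound 4 (0.12 log units; within the scatter). For compound 4 the estimated value is 200 nM, with an expected range from 60 nM to 700 nM.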

Compound 4, concentration for 50% growth inhibition: 394 nM
Beside the measured number, compound 4's estimate is 2.0-fold (0.29 log units) below it; the measured number falls inside the stated range.
By their numbers in this assay, from the lowest: compound 2; then compound 4; then compound 1; then compound 3.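

In this assay, the sulfonamide nitrogen now has its first direct reading: going from methylsulfamoyl to sulfamoyl gives a 2.6-fold higher number from compound 2 to compound 4 (0.42 log units; beyond the scatter), a modest step but one beyond the scatter. This position therefore responds to the loss of a single methyl, and within this pair the methyl-bearing compound has the lower number. No measurement on hand bears on why the number rises.

On these data alone, with only hydrogen and methyl compared on this nitrogen, it remains open whether a longer chain such as propyl, or a hydroxyethyl group, would lower the number further or raise it. Also open, as far as these compounds go, is whether the same change would give a similar step with a different group on the shared core, since the series holds just this one pair.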